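The compounds below may be only part of what the source reports. "The series", "measured", "known", "first", "only" and "open" are said of these compounds alone.

Compound 3 `COc1ccc(S(=O)(=O)Nc2ccc3oc(-c4ccc(NC(=O)c5cccc(C)c5[N+](=O)[O-])cc4)nc3c2)cc1` gives 72000 nM in an assay on mitochondria for inhibition of HSP60/HSP10 (Homo sapiens) (a lower number here means a stronger inhibitor, a higher number a weaker inhibitor), the higher of the two numbers shown. Compound 2 `COc1ccc(S(=O)(=O)Nc2ccc3oc(-c4ccc(NS(=O)(=O)c5cc(Br)ccc5OC)cc4)nc3c2)cc1` gives 67000 nM in this assay, and the step reads a 1.1-fold higher number from compound 2 to compound 3 (0.03 log units; within the scatter). Compound 1 `COc1ccc(S(=O)(=O)Nc2ccc3oc(-c4ccc(NS(=O)(=O)c5cc(F)ccc5OC)cc4)nc3c2)cc1` in this assay reaches only a limit, > 100000 nM (the limit of > 100000 nM in this assay, at which 1 of the 3 values shown sits). From that limit, an at least 1.4-fold lower number from compound 1 to compound 2 (0.17 log units; that floor lies within the scatter) and an at least 1.3-fold lower number from compound 1 to compound 3 (0.14 log units; that floor lies within the scatter) set floors that lie within the scatter. Compound 4 `COc1ccc(S(=O)(=O)Nc2ccc3oc(-c4ccc(NC(=O)C5CCN(C(C)=O)CC5)cc4)nc3c2)cc1` is unmeasured; it differs from compound 3 in that (1-acetylpiperidin-4-yl in place of 3-methyl-2-nitrophenyl on a carbonyl carbon). Among the compounds with values here, no measured step replaces an aromatic ring on this carbonyl carbon with a non-aromatic one, and all measured steps sit within the scatter, so no shift beyond the scatter is expected in this assay. Compound 4 is estimated at 90000 nM, within 35000 nM to 250000 nM. The expected step is a 1.3-fold higher number from compound 3 to compound 4 (0.10 log units; within the scatter).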

Compound 4, half-maximal inhibitory concentration: 24000 nM
Beside the measured number, compound 4's estimate is 3.8-fold (0.57 log units) above it, outside the stated range (below it).
By their numbers in this assay, from the lowest: compound 4; then compounds 2 and 3 (each within the scatter of the next). At a limit, above all of these: compound 1.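

Notes on the carbonyl carbon position: 1-acetylpiperidin-4-yl in place of 3-methyl-2-nitrophenyl gives the first step in this assay beyond the scatter, a 3.0-fold lower number from compound 3 to compound 4 (0.48 log units; beyond the scatter), so an aromatic ring is not needed here for this level of inhibition. Against a sulfonyl partner the shift reads a 2.8-fold lower number from compound 2 to compound 4 (0.45 log units; beyond the scatter). Compound 1 stands only at a limit, so an at least 4.1-fold lower number from compound 1 to compound 4 (0.61 log units; beyond the scatter) is a floor: the limit of > 100000 nM in this assay, at which 1 of the 4 values shown sits.

Open, as far as these compounds go, is whether the lower number follows the non-aromatic ring or its acetyl group. A cyclohexyl group or a piperidin-4-yl group with a free amine on this carbonyl carbon would separate the two.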